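Amide to Sulfonamide: Expected Cytotoxicity of Compound 4

A few compounds are considered here, and "the series" means these few. Any claim that something is new, unique, unknown or untested is made for them only; others in the source may bear on it.

Compound 1 `CC(C)(C)OC(=O)Nc1ncc(C(Oc2ccc(OCc3ccccc3)cc2)c2ccc(Cl)cc2)s1` gives > 50000 nM in an ADME assay on HepG2 2.2.15 cells (Homo sapiens) for cytotoxicity; a lower number here means that less compound is tolerated, a higher number that more compound is tolerated; this is a limit of the assay, not a number.
Compound 2 `O=C(Nc1ncc(C(OCc2ccc(F)cc2Br)c2ccccc2)s1)c1cccs1` gives "not toxic" (no number reported).
Compound 3 `CC(C)(C)C(=O)Nc1ncc(C(Oc2ccc3cc(Br)ccc3c2)c2ccc(Cl)cc2)s1` gives "not toxic" (no number reported).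

Compound 3 thus has no single number in this assay; of the two other values, one is a limit of > 50000 nM in this assay, at which 1 of the 3 values shown sits, and the other also carries no number. No pair among these three compounds differs in only one place, so no measured step exists. Compound 4 `O=S(=O)(Nc1ncc(C(Oc2ccc3cc(Br)ccc3c2)c2ccc(Cl)cc2)s1)c1cccs1` is not yet measured; it differs from compound 3 by (thiophen-2-yl)sulfonyl in place of (tert-butyl)carbonyl on a nitrogen on an aromatic ring. With all three known entries showing no toxicity within the tested range, the step from compound 3 to compound 4 is expected to be none beyond the usual scatter. Compound 4 is therefore expected to give 50000 nM, within 20000 nM to 100000 nM, most likely reported again only as a limit.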

Compound 4, half-maximal cytotoxic concentration: "not toxic" (no number reported)
The entry for compound 4 holds no number; there is nothing to compare the estimate with.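

Within the data shown here, compound 3 and compound 4 both carry only the entry "not toxic" in this assay, and no step between them can be read. The compounds shown leave open at what concentration, if any, either one harms these cells.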